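Moving the thiophene link at the assay limit

The source may report more compounds than this note shows. Statements on the series, on what has been measured and on what is new or still open speak of the compounds shown alone.

Compound 1 `Cc1nc(N)c2c(-c3ccoc3)cn([C@@H]3O[C@H](CO)[C@@H](O)[C@H]3O)c2n1` and compound 2 `Cc1nc(N)c2c(-c3cccs3)cn([C@@H]3O[C@H](CO)[C@@H](O)[C@H]3O)c2n1` share one core. In a functional assay on HL-60 cells (Homo sapiens) for antiproliferative activity, read by XTT assay, with a stated time of 72 h (on this read-out higher numbers stand for weaker inhibition and lower numbers for stronger inhibition), compound 1 gives > 20000 nM as its reading, which is a limit of the assay and not a number. Compound 2 gives > 20000 nM as its reading, again a limit and not a number. Compound 2 therefore stands at the limit of > 20000 nM in this assay, at which 2 of the 2 values shown sit, and has no exact position.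

Compound 3 `Cc1nc(N)c2c(-c3ccsc3)cn([C@@H]3O[C@H](CO)[C@@H](O)[C@H]3O)c2n1` keeps the core and changes one group: thiophen-3-yl in place of thiophen-2-yl on an aromatic carbon with thiophen-3-yl in place of thiophen-2-yl on an aromatic carbon. Within the data shown here, the only measured step that bears on this change is a step that the two limits leave unreadable from compound 1 to compound 2 and it offers no size to carry over. In this assay no shift beyond the scatter is therefore expected, and the estimated step is a number no higher from compound 2 to compound 3 (the limit leaves the size open) in size. For compound 3 the estimate is 20000 nM as a middle value, with an expected range from 6000 nM to 50000 nM for repeated measurements.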

Compound 3, half-maximal inhibitory concentration: > 20000 nM
Compound 3 ended at the assay's limit; the forecaster's own chance of this, stated with the estimate: 80%; the middle value sits exactly at the limit.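

In this assay compound 3 gives > 20000 nM, a limit and not a number. No step among compound 1, compound 2 and compound 3 can be read, since all three share one limit: the limit of > 20000 nM in this assay, at which 3 of the 3 values shown sit.

The compounds shown leave open whether furan-3-yl, thiophen-2-yl and thiophen-3-yl differ at all in this read-out.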